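The source may report more compounds than this note shows. Statements on the series, on what has been measured and on what is new or still open speak of the compounds shown alone.

Two compounds share one core and differ only in the group carried on the amide nitrogen. Compound 1 `COc1cc2cc(C(=O)NCc3ccc(F)cc3)c(=O)oc2cc1OCCCOc1no[n+]([O-])c1S(=O)(=O)c1ccccc1` bears a 4-fluorobenzyl group there; in a functional assay on MCF7 cells (Homo sapiens) for inhibition, read by MTT assay, with a stated time of 48 h (a higher number here means a weaker inhibitor, a lower number a stronger inhibitor), compound 1 gives 370 nM. Compound 2 `COc1ccc(NC(=O)c2cc3cc(OC)c(OCCCOc4no[n+]([O-])c4S(=O)(=O)c4ccccc4)cc3oc2=O)cc1` bears a 4-methoxyphenyl group instead, and in this assay compound 2 gives 410 nM. Going by the values given here, compound 2 holds the highest of the two numbers so far, but the only step between them, a 1.1-fold higher number from compound 1 to compound 2 (0.04 log units; within the scatter), lies within the scatter, so the two are not told apart by this measurement.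

Compound 3 `COc1cc2cc(C(=O)NCc3ccccc3)c(=O)oc2cc1OCCCOc1no[n+]([O-])c1S(=O)(=O)c1ccccc1` has not yet been measured. The change from compound 2 to compound 3 is benzyl in place of 4-methoxyphenyl on an amide-type nitrogen. Among the compounds with values here, the single measured step that bears on it, a 1.1-fold higher number from compound 1 to compound 2 (0.04 log units; within the scatter), also exchanged one amide substituent for another and left the number essentially unchanged; compound 3 carries a benzyl group, which is closer in name to the 4-fluorobenzyl of compound 1 than to the 4-methoxyphenyl of compound 2. The step from compound 2 to compound 3 is therefore expected to be a 1.1-fold lower number from compound 2 to compound 3 (0.02 log units; within the scatter), with no direction beyond the scatter. Compound 3 is estimated to give 390 nM in this assay, within a range of 190 nM to 800 nM.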

Compound 3, half-maximal inhibitory concentration: 740 nM
For compound 3 the middle estimate is 1.9-fold (0.28 log units) below the measured one, and the stated range covers the measured number.
By their numbers in this assay, from the lowest: compounds 1, 2 and 3 (each within the scatter of the next).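

Benzyl in place of 4-methoxyphenyl on the amide-type nitrogen gives a 1.8-fold higher number from compound 2 to compound 3 (0.26 log units; within the scatter) in this assay and so, like the exchange between compound 1 and compound 2, this change does not tell its two compounds apart. Compound 3 also allows a reading of a smaller change, confined to the aromatic ring of the benzyl group: hydrogen in place of fluoro on an aromatic carbon gives a 2.0-fold higher number from compound 1 to compound 3 (0.30 log units; within the scatter) and this step too is within the scatter, so the fluoro group has no effect here that this measurement can separate from repeat variation. Across these three compounds the amide nitrogen thus carries a 4-fluorobenzyl, a 4-methoxyphenyl or a benzyl group without any step beyond the scatter, and nothing shown offers a reason for the numbers.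

All three substituents contain one six-membered aromatic ring of carbon only, so what the compounds shown leave open is how the number responds to a group without such a ring, such as a methyl group or a chain ending in an amine. Also open, on these data alone, is whether a carboxylic acid on the aromatic ring would give a step beyond the scatter.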